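The compounds below may be only part of what the source reports. "The series", "measured", "known", "first", "only" and "open" are said of these compounds alone.

Among the compounds with values here, compound 1 `Nc1ccccc1NC(=O)/C=C/c1ccc(CSc2ccc(F)cc2)cc1` sits at the low end of the two numbers so far: in a functional assay on SMMC-7721 cells (Homo sapiens) for inhibition, read by CCK-8 assay, with a stated time of 72 h, tested at 2 uM (a lower number here means less inhibition of growth, a higher number more inhibition of growth at the concentration tested), compound 1 gives 18.3%. Compound 2 `Cc1ccc(SCc2ccc(C(=O)Nc3ccccc3N)cc2)cc1` lies close to it, since in this assay compound 2 gives 25.1%, a gap that stays within the usual scatter. Compound 3 `Nc1ccccc1NC(=O)/C=C/c1ccc(CSc2cccc3ccccc23)cc1` differs from compound 1 in one place: naphthalen-1-yl in place of 4-fluorophenyl on a sulfur. Within the data shown here, with no measured step of this kind to lean on, the change from compound 1 to compound 3 is expected to be small, a number 3.7 percentage points higher from compound 1 to compound 3 (within the scatter), and not clearly beyond the scatter. Compound 3 is therefore estimated at 22%, within a range from 8% to 40%.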

Compound 3, percent growth inhibition at one concentration: 3.7%
Compound 3: middle estimate off by 18.3 percentage points, on the high side; measured number outside the range, below it.
By their numbers in this assay, from the lowest: compound 3; then compounds 1 and 2 (each within the scatter of the next).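

In this assay, naphthalen-1-yl in place of 4-fluorophenyl on a sulfur gives a number 14.6 percentage points lower from compound 1 to compound 3 (beyond the scatter), so the group on this sulfur can change growth inhibition at the concentration tested. The step adds a second aromatic ring and removes the fluorine at once, so the compounds shown cannot separate these two changes. No measurement here explains the drop. Open, on these data alone, is how a plain phenyl or a naphthalen-2-yl on this sulfur would compare, which would help separate the two changes. A carboxylic acid or an amine on the phenyl ring is also left open.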